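Swapping the Amide Side Group of Compound 1

The compounds below may be only part of what the source reports. "The series", "measured", "known", "first", "only" and "open" are said of these compounds alone.

Compound 1 `C[C@@H]1CN(c2sc(C(F)(F)F)nc2-c2nc3ccccc3[nH]2)CCN1C(=O)Cn1cnc2c1CCN(C)C2` is measured in a functional assay on CHO-K1 cells for antagonist activity at C-X-C chemokine receptor type 3 (Homo sapiens), read by FLIPR, with a stated time of 10 min, in the presence of a further agent that is not named here (on this read-out higher numbers stand for weaker inhibition and lower numbers for stronger inhibition), where compound 1 gives 3.6 nM. That is the lowest of the three numbers recorded; compound 2 `Cc1nc(C)n(CC(=O)N2CCN(c3sc(C(F)(F)F)nc3-c3nc4c(C(F)(F)F)cccc4[nH]3)C[C@H]2C)n1` gives 6 nM, which lies within the scatter of compound 1, whereas compound 3 `Cc1nc(C)n(CC(=O)N2CCN(c3sc(C(F)(F)F)nc3-c3nc4ccc(C(C)(C)O)c(F)c4[nH]3)C[C@H]2C)n1` gives 9.4 nM, beyond the scatter. Compound 4 `COC1CCN(CC(=O)N2CCN(c3sc(C(F)(F)F)nc3-c3nc4ccccc4[nH]3)C[C@H]2C)C1` differs from compound 1 in one place, (a group of 7 heavy atoms (5 carbon, 1 nitrogen, 1 oxygen; one five-membered non-aromatic ring with 1 hetero atom) in place of a group of 10 heavy atoms (7 carbon, 3 nitrogen; one five-membered aromatic ring with 2 hetero atoms, one six-membered non-aromatic ring with 1 hetero atom), on a saturated chain carbon bound to a carbonyl carbon). For the measured compounds named here, no measured pair shows this change, so its effect is uncertain. Because the three compounds, with compound 1 at 3.6 nM, all carry a ring-bearing group at this position, the smaller saturated ring is expected to cost some activity; a moderate rise in the number is expected, a 4.2-fold higher number from compound 1 to compound 4 (0.62 log units; beyond the scatter). Compound 4 is estimated at 15 nM, ranging from 5 nM to 50 nM.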

Compound 4, half-maximal inhibitory concentration: 42 nM
The estimate for compound 4 lay 2.8-fold (0.45 log units) below the measured number, and the stated range covers the measured number.
By their numbers in this assay, from the lowest: compounds 1, 2 and 3 (each within the scatter of the next, the first and the last beyond it); then compound 4.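

In this assay, putting 3-methoxypyrrolidin-1-yl in place of the two-ring group of compound 1 gives a 12-fold higher number from compound 1 to compound 4 (1.07 log units; beyond the scatter), a large step and the first one that can be read at this position. The group on the saturated chain carbon bound to a carbonyl carbon therefore matters strongly to the number. No data shown here bear on the cause of this step. Since the aromatic ring, the second ring and the methoxy group all change together, the step cannot be divided among them. An unsubstituted pyrrolidine or a simple imidazole at this position would separate these changes.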